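The compounds below may be only part of what the source reports. "The series", "measured", "known", "first", "only" and "open" are said of these compounds alone.

Measured so far in a functional assay on the whole organism (strain Swiss) with Mus musculus as the target, in the maximal electroshock model, with a stated time of 1 h, at a dose of 300 mg/kg by the intraperitoneal route; a higher number here means a stronger effect of the compound at the dose given, a lower number a weaker effect:
- compound 1, `CC(C(=O)N1CCN(c2cccc(Cl)c2)CC1)N1C(=O)CCC1=O`, gives 75%
- compound 2, `CCC(C(=O)N1CCN(c2cccc(C(F)(F)F)c2)CC1)N1C(=O)CCC1=O`, gives 100%
- compound 3, `Cc1cccc(N2CCN(C(=O)C(C)N3C(=O)CCC3=O)CC2)c1`, gives 0%

Compound 3 stands lowest of these three numbers. For the measured compounds named here, its nearest neighbour is compound 1, and the only single-change step among the measured compounds runs between them: a number 75 percentage points lower from compound 1 to compound 3 (beyond the scatter). Compound 2 gives the highest of the three values, and its gap to compound 3 is the widest.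

The compound still to be measured is compound 4, `CC(C(=O)N1CCN(c2cccc(C(F)(F)F)c2)CC1)N1C(=O)CCC1=O`. It differs from compound 3 in one place: trifluoromethyl in place of methyl on an aromatic carbon. The step from compound 1 to compound 3 bears on this change, since it shows that on the same aromatic carbon, exchanging chloro for methyl cost a large amount of activity; compound 4 puts a different group, trifluoromethyl, on that carbon in place of methyl. Compound 2 also carries trifluoromethyl on an aromatic carbon and gives 100%, although it is not a single step away from compound 4.

On this basis a large step upward is expected in this assay, of about a number 85 percentage points higher from compound 3 to compound 4 (beyond the scatter). For compound 4 the estimated value is 85%, with a range from 50% to 100%.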

Compound 4, a percentage reported as activity, at one dose (the size of the read-out at that dose, not a potency): 100%
For compound 4 the middle estimate is 15 percentage points below the measured one, and the stated range covers the measured number.
By their numbers in this assay, from the lowest: compound 3; then compound 1; then compounds 2 and 4 (each within the scatter of the next).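

In this assay trifluoromethyl in place of methyl on this aromatic carbon gives a number 100 percentage points higher from compound 3 to compound 4 (beyond the scatter) and so shows that the whole range of the read-out can turn on this one group. Trifluoromethyl also outperforms chloro on the same carbon, with a number 25 percentage points higher from compound 1 to compound 4 (beyond the scatter) and this puts the three groups in order for compound 3, compound 1 and compound 4 alone, with methyl lowest, chloro in the middle and trifluoromethyl highest. The saturated chain carbon behaves quite differently when trifluoromethyl sits on the aromatic ring, since hydrogen in place of methyl there gives no change at the digits printed from compound 2 to compound 4 (within the scatter) and at this dose that change leaves no visible mark on the effect.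

Still open, from the compounds shown here alone, is how other groups on the aromatic carbon, such as a nitrile or a methoxy group, would compare, and whether a longer chain on the saturated chain carbon would hold up with chloro or methyl on the ring. Nothing in the data shown accounts for why these aromatic groups part so sharply.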